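Adding a methyl group to a lipophilic benzothiazole hydrazone

The compounds below may be only part of what the source reports. "The series", "measured", "known", "first", "only" and "open" are said of these compounds alone.

The compounds measured so far:
- compound 1, `Clc1ccc(Oc2ccc(/C=N/Nc3nc4ccccc4s3)cc2)cc1`: 5.6
- compound 2, `O=C(CSc1nc2ccccc2s1)N/N=C/c1ccc(Oc2ccc(Cl)cc2)cc1`: 5.6
- compound 3, `O=C(CSc1nc2ccccc2s1)N/N=C1\C(=O)Nc2ccccc21`: 3.2

These three compounds were examined in a physicochemical assay for lipophilicity, in phosphate buffer, measured as octanol-water partition, with a stated time of 24 h; a higher number here means a more lipophilic compound, a lower number a more polar compound. In this assay compound 2 gives 5.6, and compound 1 gives 5.6, which is the same number at the digits shown, so the two are level within the usual scatter and together sit at the top of the three. Compound 3, which lacks the chlorophenoxy-phenyl part, gives 3.2, a far lower number that lies well beyond the scatter.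

The next compound, compound 4, `Cc1cc(Oc2ccc(/C=N/NC(=O)CSc3nc4ccccc4s3)cc2)ccc1Cl`, differs from compound 2 in one place: methyl in place of hydrogen on an aromatic carbon. Nothing measured here tells how such a change moves this assay, so the expectation rests on the change itself. A small upward step, a number 0.40 log units higher from compound 2 to compound 4 (beyond the scatter), is expected, probably just beyond the scatter. Compound 4 is therefore estimated at 6, likely between 5.6 and 6.5.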

Compound 4, partition coefficient: 5.7
Estimate against measurement, compound 4: 0.30 log units above; low and high end bracket the measured number.
By their numbers in this assay, from the lowest: compound 3; then compounds 1, 2 and 4 (each within the scatter of the next).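

In this assay, for the compounds shown here, the change from 4-chlorophenoxy to 4-chloro-3-methylphenoxy gives a number 0.10 log units higher from compound 2 to compound 4 (within the scatter) and is the first single change that can be read directly. At this place, ortho to a chloro group and meta to a large group, methyl in place of hydrogen adds one carbon, yet leaves compound 4 level with compound 2 in this measurement. The data offer no explanation for why the two compounds stay level.

Going by these compounds, whether an ethyl group, a longer chain or an amine at the same place would also leave the number level remains open. On these data alone, it is also open whether the same methyl change would read the same way on compound 1, whose link to the shared core is different.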